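The compounds below may be only part of what the source reports. "The series", "measured", "known", "first", "only" and "open" are said of these compounds alone.

In a functional assay on the whole organism (strain Swiss) with Mus musculus as the target, in the maximal electroshock model, with a stated time of 1 h, at a dose of 300 mg/kg by the intraperitoneal route (a higher number here means a stronger effect of the compound at the dose given, a lower number a weaker effect), compound 2 `COc1cccc(N2CCN(C(=O)C(C)N3C(=O)CCC3=O)CC2)c1` gives 0%. Compound 3 `CCC(C(=O)N1CCN(c2cccc(OC)c2)CC1)N1C(=O)CCC1=O` gives 0% in this assay, and the step of no change at the digits printed from compound 2 to compound 3 (within the scatter) shows that lengthening the chain group changes nothing at this level, so compound 2 and compound 3 together hold the lowest of the three numbers. Compound 1 `CCC(C(=O)N1CCN(c2ccccc2F)CC1)N1C(=O)CCC1=O` gives 50% in this assay, and the step of a number 50 percentage points lower from compound 1 to compound 3 (beyond the scatter) is the only large movement among the measured compounds.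

Compound 4 `CC(C(=O)N1CCN(c2cccc(F)c2)CC1)N1C(=O)CCC1=O` differs from compound 2 in one place: fluoro in place of methoxy on an aromatic carbon. Among the measured compounds shown here, no measured step makes exactly this exchange. The step from compound 1 to compound 3 does swap a fluorine-bearing ring for a methoxy-bearing ring, but it changes 2-fluorophenyl to 3-methoxyphenyl, which is more than the group alone, so it bears on the question only loosely. An upward step a number 20 percentage points higher from compound 2 to compound 4 (beyond the scatter) is expected, with wide uncertainty, because compound 1 with its fluorine-bearing ring gives 50%. Compound 4 is therefore estimated to give 20%, within a range from 0% to 50%.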

Compound 4, a percentage reported as activity, at one dose (the size of the read-out at that dose, not a potency): 75%
Compound 4: the middle estimate sits 55 percentage points below what was measured; measured number above the stated range.
By their numbers in this assay, from the lowest: compounds 2 and 3 (each within the scatter of the next); then compound 1; then compound 4.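

In this assay, the exchange of methoxy for fluoro on an aromatic carbon, meta to a large group, gives a number 75 percentage points higher from compound 2 to compound 4 (beyond the scatter) and is a large step. The earlier comparison of a 2-fluorophenyl with a 3-methoxyphenyl group changed the group and its place together, whereas here the place stays fixed and the group alone moves the read-out from nothing to a clear effect. Nothing available explains why this single exchange gives such a step.

The compounds shown leave open whether chloro, methyl or hydroxyl at this same place would match fluoro. They also leave open how a 3-fluorophenyl group behaves when paired with the longer chain group of compound 3, where the methoxy pair showed no difference.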